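Hydroxy in Place of Nitro on a Weak Cortical Binder

This account rests on a few compounds, and the source may have more. Where it says the series, first, only, none or still open, it means among the compounds named here.

Compound 2 `CN1CCC[C@H]1[C@@H]1COc2cc([N+](=O)[O-])ccc2O1` was examined in an assay on membranes from Cerebral cortex for displacement of a labelled ligand from Neuronal acetylcholine receptor; alpha4/beta2 (Rattus norvegicus), with a stated time of 5 min (a higher number here means a weaker inhibitor, a lower number a stronger inhibitor), where compound 2 gives 46000 nM, the lowest of the two numbers in hand. Its nearest neighbour is compound 1 `CN1CCC[C@H]1[C@@H]1COc2cc(N)ccc2O1`, and in this assay compound 1 gives 86000 nM. That step is a 1.9-fold lower number from compound 1 to compound 2 (0.27 log units; within the scatter). Compound 3 `CN1CCC[C@H]1[C@H]1COc2cc([N+](=O)[O-])ccc2O1` reaches only the limit of > 100000 nM in this assay. The step there is an at least 2.1-fold higher number from compound 2 to compound 3 (0.33 log units; beyond the scatter), which rests on (the fact that compounds 2 and 3 differ only in the configuration as drawn). The unmeasured compound 4 `CN1CCC[C@H]1[C@@H]1COc2cc(O)ccc2O1` carries hydroxy in place of nitro on an aromatic carbon. Going by the values given here, the single step that swapped a group at this place, a 1.9-fold lower number from compound 1 to compound 2 (0.27 log units; within the scatter), stayed within the scatter, so no change beyond the scatter is expected. Compound 4 is therefore expected to show a 1.3-fold higher number from compound 2 to compound 4 (0.12 log units; within the scatter) in this assay. Compound 4 is estimated at 60000 nM, with a range from 20000 nM to 180000 nM.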

Compound 4, inhibition constant: 50000 nM
Estimate against measurement, compound 4: 1.2-fold (0.08 log units) above; low and high end bracket the measured number.
By their numbers in this assay, from the lowest: compounds 2, 4 and 1 (each within the scatter of the next). At a limit, above all of these: compound 3.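

With hydroxy at this aromatic carbon, this assay now covers three groups at one place, and none stands apart from the others (a 1.1-fold higher number from compound 2 to compound 4 (0.04 log units; within the scatter); a 1.7-fold lower number from compound 1 to compound 4 (0.24 log units; within the scatter)). Nitro, amino and hydroxy thus read alike here, so no swap at this place has yet moved the number beyond the scatter. The data shown offer no reason for this sameness. Going by these compounds, whether a carboxylic acid or a longer chain at this carbon would change the number stays open. So does whether hydroxy, like nitro, is sensitive to the configuration at the saturated ring carbon.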